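The source may report more compounds than this note shows. Statements on the series, on what has been measured and on what is new or still open speak of the compounds shown alone.

In a functional assay on HepG2 cells (Homo sapiens) for antiproliferative activity, read by MTT assay, with a stated time of 72 h (on this read-out higher numbers stand for weaker inhibition and lower numbers for stronger inhibition), compound 1 `COc1ncc(-c2ccc3c(c2)NC(=O)CO3)cc1NS(=O)(=O)c1ccc(F)cc1` gives 6590 nM. Compound 2 `COc1ncc(-c2ccc3c(c2)N(C2CCCCC2)C(=O)CO3)cc1NS(=O)(=O)c1ccc(F)cc1` gives > 40000 nM, which is only a limit and not a number. Compound 3 `COc1ncc(-c2ccc3c(c2)N(c2ccc(Cl)cc2)C(=O)CO3)cc1NS(=O)(=O)c1ccc(F)cc1` changes the group on the amide-type nitrogen in a ring: 4-chlorophenyl in place of cyclohexyl on an amide-type nitrogen in a ring. Among the compounds with values here, the one measured step bearing on this, an at least 6.0-fold higher number from compound 1 to compound 2 (0.78 log units; beyond the scatter) with cyclohexyl in place of hydrogen on that nitrogen, leads to an expectation of weak inhibition for compound 3, which also keeps a ring there. The expected step is an at least 1.3-fold lower number from compound 2 to compound 3 (0.12 log units; that floor lies within the scatter), with none expected beyond the scatter. Compound 3 is estimated at 30000 nM, with an expected range from 9000 nM to 70000 nM.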

Compound 3, half-maximal inhibitory concentration: 17900 nM
The estimate for compound 3 lay 1.7-fold (0.22 log units) above the measured number; the measured number falls inside the stated range.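

On the amide-type nitrogen in a ring, the group placed there matters, not just whether one is present: 4-chlorophenyl in place of cyclohexyl gives an at least 2.2-fold lower number from compound 2 to compound 3 (0.34 log units; beyond the scatter) in this assay. Compound 2 has a limit and not a number, so this step is only a floor: the limit of > 40000 nM in this assay, at which 1 of the 3 values shown sits. Even so, 4-chlorophenyl does not recover the level seen with the hydrogen, giving a 2.7-fold higher number from compound 1 to compound 3 (0.43 log units; beyond the scatter).

Going by these compounds, whether a methyl or a longer chain on this nitrogen would come closer to compound 1 stays open. The compounds shown also cannot separate the effect of the chlorine from that of the aromatic ring.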